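A few compounds are considered here, and "the series" means these few. Any claim that something is new, unique, unknown or untested is made for them only; others in the source may bear on it.

Compound 1 `Cc1ccc(COc2ccc(-c3nn(CCC#N)c(=O)o3)cc2)cc1`: 15 nM
Compound 2 `N#CCCn1nc(-c2ccc(OCc3cccc(Cl)c3)cc2)oc1=O`: 12 nM
Compound 3 `Cc1ccc(COc2ccc(C3=NN(CCC#N)C(=O)CO3)cc2)cc1`: 320 nM

Of the compounds shown here, three have been measured in an assay for inhibition of Amine oxidase [flavin-containing] B (Rattus norvegicus); on this read-out higher numbers stand for weaker inhibition and lower numbers for stronger inhibition. Compound 1 and compound 2 share one core, and compound 3 carries a different core; the difference between the two cores is not broken down here. Compound 3 gives the highest of the three numbers in this assay, standing well beyond the scatter from both compound 1 and compound 2.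

Between compound 1 and compound 2 there is a single change, (3-chlorophenyl in place of 4-methylphenyl on a saturated chain carbon bound to an oxygen on an aromatic ring), and the measured step is a 1.3-fold lower number from compound 1 to compound 2 (0.10 log units; within the scatter). The two values therefore sit within the scatter of each other and no order between them is claimed.

Compound 4 `N#CCCN1N=C(c2ccc(OCc3cccc(Cl)c3)cc2)OCC1=O` is not yet measured. It differs from compound 3 by 3-chlorophenyl in place of 4-methylphenyl on a saturated chain carbon bound to an oxygen on an aromatic ring, which is the same change as that from compound 1 to compound 2, at the same place. Because the step of a 1.3-fold lower number from compound 1 to compound 2 (0.10 log units; within the scatter) was small, the expectation for compound 4 rests on carrying that step over to the core of compound 3, whose own number is 320 nM. The estimated step is a 1.3-fold lower number from compound 3 to compound 4 (0.11 log units; within the scatter). On that basis compound 4 is expected to give about 250 nM in this assay, with a plausible range from 100 nM to 650 nM, since only one earlier example of this change supports the transfer and the core of compound 3 has shown no other changes yet.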

Compound 4, half-maximal inhibitory concentration: 13 nM
Estimate against measurement, compound 4: 19-fold (1.28 log units) above, and the stated range ends above it.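

In this assay, the change from 4-methylphenyl to 3-chlorophenyl gives a 25-fold lower number from compound 3 to compound 4 (1.39 log units; beyond the scatter), so this change does not carry over as a step of fixed size from one core to the other: the same change on two cores in this assay, a 1.3-fold lower number (0.10 log units; within the scatter) from compound 1 to compound 2 and a 25-fold lower number (1.39 log units; beyond the scatter) from compound 3 to compound 4, 20-fold (1.29 log units) apart, beyond the scatter of two such steps With 3-chlorophenyl in place, compound 2 gives 12 nM and compound 4 gives 13 nM, while the two 4-methylphenyl compounds stand apart, with compound 1 at 15 nM and compound 3 at 320 nM. This shows only that the effect of the change depends on the core in this one pair of pairs; it does not show why, and with a single example on each core it gives no general rule for other groups or other cores.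

The compounds shown leave open whether the large step on the core of compound 3 comes from gaining the chlorine or from losing the methyl, and a plain phenyl or a 4-chlorophenyl at the same place on both cores would bear on that. They also leave open how either core responds when the chain ending in the nitrile is replaced, for instance by a longer chain or one ending in a carboxylic acid.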